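From Fluoromethyl to Carboxy on a Shared Core

A few compounds are considered here, and "the series" means these few. Any claim that something is new, unique, unknown or untested is made for them only; others in the source may bear on it.

Compound 1, `C/C(=N\OCc1ccncc1)c1ccc(Sc2cc(F)cc(C3CCOCC3)c2)cc1`: in a functional assay (blood) for inhibition, with Homo sapiens as the target (a lower number here means a stronger inhibitor, a higher number a weaker inhibitor), compound 1 gives 300 nM.
Compound 2, `CC(C)/C(=N\O)c1ccc(Sc2cc(F)cc(C3CCOCC3)c2)cc1`: in this assay compound 2 gives 300 nM.
Compound 3, `C/C(=N\OCCF)c1ccc(Sc2cc(F)cc(C3CCOCC3)c2)cc1`: in this assay compound 3 gives 40 nM.

Compound 3 stands lowest of the three numbers, its steps to both others lying beyond the scatter. Compound 4, `C/C(=N\OCC(=O)O)c1ccc(Sc2cc(F)cc(C3CCOCC3)c2)cc1`, has not yet been measured. It differs from compound 3 in one place: carboxy in place of fluoromethyl on a saturated chain carbon bound to an oxygen.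

Going by the values given here, two measured steps touch the same region of the core. Compound 1 to compound 3 gave a 7.5-fold lower number from compound 1 to compound 3 (0.88 log units; beyond the scatter), and compound 2 to compound 3 gave a 7.5-fold lower number from compound 2 to compound 3 (0.88 log units; beyond the scatter). Among the compounds with values here, both show that a change at this end of the molecule can move the number by a clear margin, yet neither swaps in a carboxy group, so the direction for compound 4 rests on no direct precedent. A modest rise in the number is expected, a 5.0-fold higher number from compound 3 to compound 4 (0.70 log units; beyond the scatter). Compound 4 is estimated at 200 nM, within a range from 50 nM to 800 nM.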

Compound 4, half-maximal inhibitory concentration: 740 nM
Compound 4: middle estimate off by 3.7-fold (0.57 log units), on the low side; the range from low to high includes it.
By their numbers in this assay, from the lowest: compound 3; then compounds 1 and 2 (each within the scatter of the next); then compound 4.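

Carboxy in place of fluoromethyl gives a 19-fold higher number from compound 3 to compound 4 (1.27 log units; beyond the scatter) in this assay and is the largest step seen so far at this end of the molecule. Carboxy also does worse than pyridin-4-yl on the same saturated chain carbon, with a 2.5-fold higher number from compound 1 to compound 4 (0.39 log units; beyond the scatter) for that swap, and the comparison with the other oxime gives a 2.5-fold higher number from compound 2 to compound 4 (0.39 log units; beyond the scatter) for that change, which makes compound 4 the weakest inhibitor of the four. Going by these compounds alone, nothing available explains why this change moves the number so far.

Still open, as far as these compounds go, is whether the loss of fluorine or the arrival of carboxy drives the step, which a plain ethyl group in place of 2-fluoroethyl could help to separate. A methyl ester or a primary amide in place of the carboxylic acid, or a longer chain ending in carboxy, would show how much of the step depends on the acid itself.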